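Cytotoxicity of three thiadiazole amides and a fourth predicted

The source may report more compounds than this note shows. Statements on the series, on what has been measured and on what is new or still open speak of the compounds shown alone.

Compound 1, `CC(Sc1nnc(-c2ccncc2)s1)C(=O)Nc1ccccc1Cl`, cytotoxicity: > 50000 nM
Compound 2, `CC(Sc1nnc(-c2ccncc2)s1)C(=O)NCc1ccccc1`, cytotoxicity: > 50000 nM
Compound 3, `O=C(CSc1nnc(-c2ccncc2)s1)Nc1ccccc1Cl`, cytotoxicity: > 50000 nM

All three compounds were tested in an ADME assay on BHK-21 cells (Mesocricetus auratus) for cytotoxicity, with a stated time of 3 days; on this read-out higher numbers stand for lower toxicity in this test and lower numbers for higher toxicity in this test. For compound 1 the value > 50000 nM is a limit of the assay, not a number. For compound 2 the value > 50000 nM is likewise a limit. For compound 3 the value > 50000 nM is again a limit. Every result sits at the limit of > 50000 nM in this assay, at which 3 of the 3 values shown sit.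

The change benzyl in place of 2-chlorophenyl on an amide-type nitrogen gave a step that the two limits leave unreadable from compound 1 to compound 2. Compound 3 and compound 1 differ in their cores by hydrogen in place of methyl on a saturated chain carbon bound to a carbonyl carbon and a sulfur, with a step that the two limits leave unreadable from compound 1 to compound 3.

Compound 4, `O=C(CSc1nnc(-c2ccncc2)s1)NCc1ccccc1`, is not yet measured. It differs from compound 3 by benzyl in place of 2-chlorophenyl on an amide-type nitrogen, the same change as from compound 1 to compound 2, made at the same place. Since compound 3 already gives only the limit > 50000 nM, the expected step that the limit leaves unreadable from compound 3 to compound 4 is essentially flat, and compound 4 is estimated at 60000 nM, most likely reported again as a limit.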

Compound 4, half-maximal cytotoxic concentration: 11300 nM
Beside the measured number, compound 4's estimate is 5.3-fold (0.73 log units) above it; the whole stated range lies above it.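

In this assay, benzyl in place of 2-chlorophenyl on an amide-type nitrogen gives an at least 4.4-fold lower number from compound 3 to compound 4 (0.64 log units; beyond the scatter), and hydrogen in place of methyl on the saturated chain carbon gives an at least 4.4-fold lower number from compound 2 to compound 4 (0.64 log units; beyond the scatter), so a lower number, meaning higher toxicity in this test, appears only when the two changes are combined in compound 4. Neither step gives an exact size, since each starts from a limit, and this result does not show that the benzyl change has the same effect on both cores. The steps among compound 1, compound 2 and compound 3 cannot be read, because all three values stop at the same limit: the limit of > 50000 nM in this assay, at which 3 of the 4 values shown sit.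

The compounds shown leave open whether benzyl would lower the number on the methyl-bearing core if the assay could read beyond that limit. They also leave open how a longer chain, such as 2-phenylethyl, or an amine would behave on the amide-type nitrogen.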